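Swapping the anilino ring on a shared core for a difluorophenyl

A few compounds are considered here, and "the series" means these few. Any claim that something is new, unique, unknown or untested is made for them only; others in the source may bear on it.

Three compounds built on one core were measured in a functional assay for agonist activity at Glucose-dependent insulinotropic receptor (Mus musculus), read by cAMP accumulation; on this read-out higher numbers stand for larger maximal responses and lower numbers for smaller maximal responses. Compound 1, `COc1c(Nc2ccc(S(C)(=O)=O)cc2F)ncnc1OC1C[C@@H]2COC[C@@H](C1)N2C(=O)OC1(C)CC1`, gives 79%. Compound 2, `CC1(OC(=O)N2CC3COCC(C2)C3Oc2ncnc(Nc3ccc(C#N)cc3Cl)c2F)CCC1`, gives 88%. Compound 3, `CC1(OC(=O)N2CC3COCC(C2)C3Oc2ncnc(Nc3cccnc3Cl)c2F)CC1`, gives 84%. On these numbers compound 3 sits between the other two: compound 2 is closest, its number a few points higher, and compound 1 is furthest, its number a few points lower, and both of these gaps lie within the usual scatter, so the three maximal responses cannot be told apart.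

Compound 4, `CC1(OC(=O)N2CC3COCC(C2)C3Oc2ncnc(Nc3ccc(F)cc3F)c2F)CC1`, has not been measured. It differs from compound 3 in one place: 2,4-difluorophenyl in place of 2-chloropyridin-3-yl on a nitrogen on an aromatic ring. Within the data shown here, no measured pair shows this kind of change, so its effect is not known from the data. Given that the three measured variations of this aromatic ring gave numbers within the scatter of each other, the step of no change at the digits printed from compound 3 to compound 4 (within the scatter) is expected to be no more than the scatter, in no particular direction. Compound 4 is therefore estimated to reach 84%, with a range from 70% to 96%.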

Compound 4, largest response reached (reported as percent of maximum), in percent of the reference or control that the assay uses: 73%
For compound 4 the middle estimate is 11 percentage points above the measured one; measured number inside the range.
By their numbers in this assay, from the lowest: compounds 4, 1, 3 and 2 (each within the scatter of the next, the first and the last beyond it).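

In this assay, replacing 2-chloropyridin-3-yl with 2,4-difluorophenyl on the nitrogen on an aromatic ring gives a number 11 percentage points lower from compound 3 to compound 4 (beyond the scatter). Among these compounds, this is the first step in the set that changes this group alone, and it shows that the maximal response can depend on which aromatic ring sits on this nitrogen, which the earlier compounds, differing in more than one place and lying within the scatter of each other, could not show. No available measurement bears on why the response shifts with this change.

As far as these compounds go, the step swaps the ring nitrogen, the chlorine and the fluorines at once, so their separate contributions remain open. A 2-chlorophenyl group on the same nitrogen of the compound 3 scaffold would begin to separate them.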